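Methylthiophene in Place of Hydroxyphenyl at the Carbonyl

This account rests on a few compounds, and the source may have more. Where it says the series, first, only, none or still open, it means among the compounds named here.

The measured compounds and their cytotoxicity values:
- Compound 1, `O=C(c1ccn(-c2ccc3c(c2)B(O)OC3)c1)c1ccccc1Cl`: in an ADME assay on L929 cells (Mus musculus) for cytotoxicity, read by resazurin assay, with a stated time of 72 h (on this read-out lower numbers stand for stronger inhibition and higher numbers for weaker inhibition), compound 1 gives > 10 ug/mL, a limit of the assay rather than a number.
- Compound 2, `Cc1cccc(C(=O)c2ccn(-c3ccc4c(c3)B(O)OC4)c2)c1`: in this assay compound 2 gives > 10 ug/mL, again a limit.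
- Compound 3, `O=C(c1ccc(O)cc1)c1ccn(-c2ccc3c(c2)B(O)OC3)c1`: in this assay compound 3 gives > 10 ug/mL, also a limit.

Compound 3 therefore stands on a limit, not on a number, and the two other values shown are limits as well. The step that the two limits leave unreadable from compound 1 to compound 2, the step that the two limits leave unreadable from compound 1 to compound 3 and the step that the two limits leave unreadable from compound 2 to compound 3 are all unreadable, because of the limit of > 10 ug/mL in this assay, at which 3 of the 3 values shown sit.

Compound 4, `Cc1ccc(C(=O)c2ccn(-c3ccc4c(c3)B(O)OC4)c2)s1`, is not yet measured. It differs from compound 3 as follows: 5-methylthiophen-2-yl in place of 4-hydroxyphenyl on a carbonyl carbon. Within the data shown here, all three measured steps bear on a change of the aryl group on the carbonyl carbon, and none could be read in size, so no direction of step in this assay can be drawn from them.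

Compound 4 is therefore expected to sit again at the same limit, with an estimated value of 15 ug/mL, a range from 5 ug/mL to 40 ug/mL, and an expected step that the limit leaves unreadable from compound 3 to compound 4.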

Compound 4, half-maximal inhibitory concentration: > 10 ug/mL
Compound 4 gave a limit, no number; the forecaster's own chance of this, stated with the estimate: 80%; the middle value is on the limit's open side.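

In this assay compound 4 gives > 10 ug/mL, a limit and not a number. The steps to compound 4 from compound 1, compound 2 and compound 3 cannot be read, because all these compounds share one limit: the limit of > 10 ug/mL in this assay, at which 4 of the 4 values shown sit. From the compounds shown here alone, what stays open is whether these aryl groups on the carbonyl carbon differ at all in this assay.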